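The source may report more compounds than this note shows. Statements on the series, on what has been measured and on what is new or still open speak of the compounds shown alone.

Measured in a functional assay on A2780 cells (Homo sapiens) for antiproliferative activity, read by CellTiter-Glo, with a stated time of 72 h (a lower number here means a stronger inhibitor, a higher number a weaker inhibitor), so far:
compound 1 `C[C@H](NC(=O)c1ncccn1)c1ccc(NC(=O)N2CC(c3cccnc3)C2)cc1` gives 36 nM
compound 2 `CCC(=O)N[C@@H](C)c1ccc(NC(=O)N2CC(c3cccnc3)C2)cc1` gives 25 nM

Compound 1 stands within the scatter of compound 2, so the pair sets no order. The next compound to be measured is compound 3 `C[C@H](NC(=O)c1ncccn1)c1ccc(NC(=O)N2CC(c3ccc(N)nc3)C2)cc1`, and it differs from compound 1 by amino in place of hydrogen on an aromatic carbon. This is pyridin-3-yl to 6-aminopyridin-3-yl, with amino in place of hydrogen on an aromatic carbon.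

For the measured compounds named here, the only measured step is a 1.4-fold lower number from compound 1 to compound 2 (0.16 log units; within the scatter). That step changes the group on the carbonyl carbon and leaves the pyridin-3-yl ring untouched, so it does not bear directly on this change. Going by the values given here, no measured compound carries a substituent on that ring. A moderate rise in this assay is therefore expected, as a tentative call with a wide margin. The expected change is a 2.5-fold higher number from compound 1 to compound 3 (0.40 log units; beyond the scatter). For compound 3 the estimate is 90 nM, with an expected range of 20 nM to 500 nM.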

Compound 3, half-maximal inhibitory concentration: 68 nM
Compound 3: the middle estimate sits 1.3-fold (0.12 log units) above what was measured, within the range that was stated.
By their numbers in this assay, from the lowest: compounds 2, 1 and 3 (each within the scatter of the next, the first and the last beyond it).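

Replacing pyridin-3-yl with 6-aminopyridin-3-yl in this assay gives a 1.9-fold higher number from compound 1 to compound 3 (0.28 log units; within the scatter). For the compounds shown here, this is the first substituent seen on this ring, and the earlier pair varied only the group on the carbonyl carbon: an amino group on this aromatic carbon, next to the ring nitrogen and para to a large group, leaves the read-out within the scatter of the unsubstituted compound 1, so the position accepts this one added nitrogen with its hydrogen-bond donor and acceptor. No measured evidence bears on why the amino group has so small an effect here.

Going by these compounds, what a methyl, a methoxy or a dimethylamino group would give at this same carbon remains open. Also open, on these data alone, is whether the amino group reads the same when ethyl stands in place of pyrimidin-2-yl on the carbonyl carbon.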